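Trifluoromethoxy for cyano: a rat exposure estimate

The source may hold more compounds than are shown below. What is called first, only, known or untested is meant among the compounds shown, and "the series" means these compounds.

Measured compounds:
- compound 1, `N#Cc1cccc(Nc2cc(C3CC3)c(C(=O)NCC3CCOCC3)cn2)c1`: "not determined" (no result reported)
- compound 2, `CC(C)(C)c1cc(Nc2ccc(Cl)cc2Cl)ncc1C(=O)NCC1CCOCC1`: 267000000 ng.h/mL

Two compounds of this series have been looked at in an ADME assay on the whole organism for pharmacokinetics, with Rattus norvegicus as the target, with a stated time of 6 h, at a dose of 30 mg/kg by the oral route; on this read-out higher numbers stand for higher exposure at the dose given and lower numbers for lower exposure. Compound 1, `N#Cc1cccc(Nc2cc(C3CC3)c(C(=O)NCC3CCOCC3)cn2)c1`, carries a cyano group on its aniline ring, but in this assay compound 1 gives "not determined" (no result reported), so no number stands for it. Compound 2, `CC(C)(C)c1cc(Nc2ccc(Cl)cc2Cl)ncc1C(=O)NCC1CCOCC1`, differs from compound 1 at several places at once, and in this assay compound 2 gives 267000000 ng.h/mL. Among the compounds with values here, with no step set out between compound 1 and compound 2, their pair shows only that one of them has been measured and the other has not.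

Compound 3, `O=C(NCC1CCOCC1)c1cnc(Nc2cccc(OC(F)(F)F)c2)cc1C1CC1`, is the untested partner of compound 1. The change is trifluoromethoxy in place of cyano on an aromatic carbon. Since compound 1 has no number in this assay, no direction or size can be assigned to this step, and the only anchor is the exposure of compound 2. Compound 3 is therefore expected to reach 50000000 ng.h/mL in this assay, within 2000000 ng.h/mL to 300000000 ng.h/mL.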

Compound 3, area under the concentration-time curve: 50000000 ng.h/mL
The estimate for compound 3 equals the measured number at the digits printed; measured number inside the range.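

Compound 3 gives 50000000 ng.h/mL in this assay but compound 1 has no number there, so no new step can be read between compound 1 and compound 3. The compounds shown leave open how trifluoromethoxy in place of cyano changes the read-out in this assay for this pair. No supporting data bear on this result.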